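The source may hold more compounds than are shown below. What is called first, only, known or untested is meant among the compounds shown, and "the series" means these compounds.

In an in vitro ADME assay on microsomes from liver (Mus musculus) for pharmacokinetics, read by LC-MS, with a stated time of 10 min, tested at 1 uM (a higher number here means faster removal of the compound, a lower number slower removal), compound 1 `Cc1ccc(NC(=O)[C@H]2CN(C)C[C@@H]2c2ccc(/C=C/C(=O)Nc3ccccc3N)cc2)cc1` gives a clearance of 62 mL/min/kg and compound 2 `Cc1cccc(NC(=O)[C@H]2CN(C)C[C@@H]2c2ccc(/C=C/C(=O)Nc3ccccc3N)cc2)c1` gives 74 mL/min/kg in the same measurement. Compound 2 therefore stands level with compound 1 within the scatter. Compound 3 `COc1cccc(NC(=O)[C@H]2CN(C)C[C@@H]2c2ccc(/C=C/C(=O)Nc3ccccc3N)cc2)c1` keeps the rest of compound 2 and differs by methoxy in place of methyl on an aromatic carbon in one place, methoxy in place of methyl on an aromatic carbon, which turns 3-methylphenyl into 3-methoxyphenyl. Within the data shown here, only one measured step bears on this ring, and it is a 1.2-fold higher number from compound 1 to compound 2 (0.08 log units; within the scatter) for 3-methylphenyl in place of 4-methylphenyl. Among the measured compounds shown here, that step is small, but no measured pair exchanges methyl for methoxy, so it offers only weak guidance. The change expected in this assay is thus none beyond the scatter, with the estimated step being a 1.1-fold lower number from compound 2 to compound 3 (0.02 log units; within the scatter) in this comparison. Compound 3 is expected to give 70 mL/min/kg (estimated range 40 mL/min/kg to 120 mL/min/kg).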

Compound 3, clearance: 65 mL/min/kg
Estimate against measurement, compound 3: 1.1-fold (0.03 log units) above, within the range that was stated.
By their numbers in this assay, from the lowest: compounds 1, 3 and 2 (each within the scatter of the next).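

In this assay, among these compounds, the first exchange of methyl for methoxy on this ring gives a 1.1-fold lower number from compound 2 to compound 3 (0.06 log units; within the scatter), so adding the oxygen and its one hydrogen-bond acceptor at this carbon leaves clearance within the scatter. Against the 4-methylphenyl amide, the 3-methoxyphenyl group gives a 1.0-fold higher number from compound 1 to compound 3 (0.02 log units; within the scatter), which places all three aryl amides within the scatter of one another. Nothing at hand explains why clearance stays level across these changes.

Going by these compounds, the three compounds carry only methyl or methoxy on this ring, so the effect on clearance of an amine or a carboxylic acid there remains open. All three also share the rest of the structure, so whether clearance in this assay responds to a change elsewhere in the molecule is not shown.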